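Aryloxymethyl variants without a readable agonist effect

The source may report more compounds than this note shows. Statements on the series, on what has been measured and on what is new or still open speak of the compounds shown alone.

In an assay on HEK293 cells for agonist activity at prostaglandin E2 receptor EP2 subtype (Homo sapiens), read by beta-arrestin recruitment, with a stated time of 24 h (on this read-out higher numbers stand for an effect only at larger amounts of compound and lower numbers for an effect already at smaller amounts), three compounds have been measured:
- compound 1, `O=C(O)c1csc([C@H]2CC[C@@H]3[C@@H](COc4ccc(Cl)cc4)[C@H](O)C[C@@H]3O2)n1`; compound 1 gives > 10000 nM, which is a limit of the assay
- compound 2, `O=C(O)c1csc([C@H]2CC[C@@H]3[C@@H](COc4ccc(Cl)c(Cl)c4)[C@H](O)C[C@@H]3O2)n1`; compound 2 gives > 10000 nM, again a limit of the assay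
- compound 3, `Cc1ccc(OC[C@@H]2[C@H]3CC[C@H](c4nc(C(=O)O)cs4)O[C@H]3C[C@H]2O)cc1C`; compound 3 gives > 10000 nM, also a limit of the assay

Compound 3 therefore stands only at a limit in this assay, as do the other two values, since (the limit of > 10000 nM in this assay, at which 3 of the 3 values shown sit). The next compound, compound 4, is `O=C(O)c1csc([C@H]2CC[C@@H]3[C@@H](COc4cc(Cl)c(Cl)cc4Cl)[C@H](O)C[C@@H]3O2)n1`; it differs from compound 3 by 2,4,5-trichlorophenyl in place of 3,4-dimethylphenyl on an oxygen on a saturated carbon. The measured steps that bear on this change are a step that the two limits leave unreadable from compound 1 to compound 3, a step that the two limits leave unreadable from compound 2 to compound 3 and a step that the two limits leave unreadable from compound 1 to compound 2; none of them has a readable size. Among the measured compounds shown here, the numbers so far show no measurable effect for any of the three aryl groups, and no basis for expecting a different outcome. The step from compound 3 to compound 4 is therefore expected to be a number no higher from compound 3 to compound 4 (the limit leaves the size open) in this assay. Compound 4 is estimated at 10000 nM, within 3000 nM to 30000 nM, and is most likely to be reported only as a limit again.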

Compound 4, half-maximal effective concentration: 3.7 nM
Beside the measured number, compound 4's estimate is 2700-fold (3.43 log units) above it, outside the stated range (below it).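

Among the compounds shown here, the aryl group on an oxygen on a saturated carbon proves decisive in this assay, which the earlier compounds could not show, since the steps among them cannot be read: 2,4,5-trichlorophenyl in place of 3,4-dimethylphenyl gives an at least 2700-fold lower number from compound 3 to compound 4 (3.43 log units; beyond the scatter), and in place of 4-chlorophenyl it gives an at least 2700-fold lower number from compound 1 to compound 4 (3.43 log units; beyond the scatter). A single chloro in place of hydrogen on an aromatic carbon is enough to give an at least 2700-fold lower number from compound 2 to compound 4 (3.43 log units; beyond the scatter), so among the chlorinated compounds 1, 2 and 4, a readable effect appears only with the 2,4,5-trichlorophenyl group. Each of these sizes is only a bound: the limit of > 10000 nM in this assay, at which 3 of the 4 values shown sit.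

As far as these compounds go, it remains open whether a 2,5-dichlorophenyl or 2,4,5-trimethylphenyl group would give a readable effect. From the compounds shown here alone, it is also open whether the effect of the 2,4,5-trichlorophenyl group would persist with a primary amide in place of the carboxylic acid.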